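Swapping a Pyridinylmethyl for a Fluorophenyl on Piperazine

A few compounds are considered here, and "the series" means these few. Any claim that something is new, unique, unknown or untested is made for them only; others in the source may bear on it.

Compound 1 `Nc1ccccc1NC(=O)c1ccc(CSC(=S)N2CCN(Cc3ccccn3)CC2)cc1`: 23.4%
Compound 2 `Nc1ccccc1NC(=O)c1ccc(CSC(=S)N2CCc3ccc([N+](=O)[O-])cc32)cc1`: 30.6%

In a functional assay on MGC-803 cells (Homo sapiens) for antiproliferative activity, read by CCK-8 assay, with a stated time of 72 h, tested at 2 uM (a lower number here means a weaker effect, a higher number a stronger effect of the compound at the concentration tested), compound 1 gives 23.4% and compound 2 gives 30.6%; the two numbers lie within the usual scatter of each other, so compound 1 cannot be ranked against compound 2. Compound 3 `Nc1ccccc1NC(=O)c1ccc(CSC(=S)N2CCN(c3ccccc3F)CC2)cc1` has not yet been measured. It differs from compound 1 by 2-fluorophenyl in place of (pyridin-2-yl)methyl on an amine nitrogen in a ring. Among the measured compounds shown here, no measured pair shows what such a change does here, so the expected step of a number 3.6 percentage points higher from compound 1 to compound 3 (within the scatter) is none beyond the scatter. Compound 3 is therefore estimated at 27% in this assay, within a range from 10% to 48%.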

Compound 3, a percentage reported as inhibition, at one concentration (the size of the read-out at that concentration, not a potency): 33.7%
For compound 3 the middle estimate is 6.7 percentage points below the measured one; the measured number falls inside the stated range.
By their numbers in this assay, from the lowest: compounds 1, 2 and 3 (each within the scatter of the next, the first and the last beyond it).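

In this assay, among the compounds shown here, the change to 2-fluorophenyl from (pyridin-2-yl)methyl gives a number 10.3 percentage points higher from compound 1 to compound 3 (beyond the scatter) and is the first step here to clear the scatter. It shows that this amine nitrogen is a place where the attached group can shift the read-out, modestly, even though both groups have 7 heavy atoms. Nothing at hand explains the rise. Still open, going by these compounds, is which part of the swap matters: the methyl link, the ring nitrogen or the fluorine. An unsubstituted phenyl or a benzyl on this nitrogen would help separate them.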